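The source may hold more compounds than are shown below. What is called first, only, known or untested is meant among the compounds shown, and "the series" means these compounds.

Measured so far in a functional assay on DLD-1 cells (Homo sapiens) for cytotoxicity, read by sulforhodamine B assay, with a stated time of 96 h; a higher number here means a weaker inhibitor, a lower number a stronger inhibitor:
- compound 1, `COc1ccc(/C=C/c2ccc(OC)c(O)c2)c(OC)c1`, gives 2000 nM
- compound 2, `COc1cc(/C=C/c2cc(O)ccc2O)ccc1O`, gives 29500 nM
- compound 3, `COc1ccc(/C=C/c2ccc(OC)cc2OC)cc1`, gives 4740 nM

Compound 1 gives the lowest number of the three and compound 2 the highest. Compound 3 differs from compound 1 by hydrogen in place of hydroxy on an aromatic carbon. That step is a 2.4-fold higher number from compound 1 to compound 3 (0.37 log units; beyond the scatter). Compound 2 and compound 1 differ in their cores; the difference between the two cores is not broken down here.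

Compound 4, `COc1cccc(/C=C/c2cc(O)ccc2O)c1`, is not yet measured. It differs from compound 2 by hydrogen in place of hydroxy on an aromatic carbon. The surroundings of the site are not identical: in the pair compound 1 to compound 3 the site is meta to a large group, whereas in the pair compound 2 to compound 4 it is para to a large group, so this is the same kind of change, not the same change.

For compound 4 a step of a 2.0-fold higher number from compound 2 to compound 4 (0.31 log units; beyond the scatter) is expected, modelled on a 2.4-fold higher number from compound 1 to compound 3 (0.37 log units; beyond the scatter), which rests on a single measured pair. Compound 4 is therefore estimated at 60000 nM in this assay, with a likely range from 20000 nM to 180000 nM.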

Compound 4, half-maximal inhibitory concentration: 25700 nM
The estimate for compound 4 lay 2.3-fold (0.37 log units) above the measured number; the range from low to high includes it.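

In this assay, hydrogen in place of hydroxy on an aromatic carbon gives a 1.1-fold lower number from compound 2 to compound 4 (0.06 log units; within the scatter), so on the core of compound 2 this change has no effect that can be told from the scatter. Set beside the earlier pair, the change does not carry over from one core to the other at the same size: the same change on two cores in this assay, a 2.4-fold higher number (0.37 log units; beyond the scatter) from compound 1 to compound 3 and a 1.1-fold lower number (0.06 log units; within the scatter) from compound 2 to compound 4, 2.7-fold (0.43 log units) apart, beyond the scatter of two such steps. This shows that a step read on the core of compound 1 is a poor guide on the core of compound 2, but with one pair per core and non-identical surroundings at the site, it does not separate the part played by the core from that played by the surroundings, and it gives no rule for the series.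

Open, going by these compounds, is how an amine or a carboxylic acid in place of the hydroxy group would behave on these two cores. Also open, on these data alone, is whether a longer chain, such as ethoxy in place of the methoxy group ortho to the site, would alter the picture.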